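The compounds below may be only part of what the source reports. "The series", "measured", "known", "first", "only" and "open" are said of these compounds alone.

Compound 1 `CCN(CC)CCNC(=O)c1ccc(C(CC)(CC)c2ccc(OCS(=O)(=O)c3ccccc3)c(C)c2)n1CC` is tested in a functional assay on PC-3 cells (Homo sapiens) for antiproliferative activity, read by MTT assay, with a stated time of 24 h (on this read-out lower numbers stand for stronger inhibition and higher numbers for weaker inhibition), where compound 1 gives 7130 nM. Compound 2 `CCn1c(C(=O)N[C@H](C)CO)ccc1C(CC)(CC)c1ccc(OCS(=O)(=O)c2ccccc2)c(C)c1` gives 7790 nM in this assay. The only difference between them lies on the amide-type nitrogen, and the step of a 1.1-fold higher number from compound 1 to compound 2 (0.04 log units; within the scatter) shows that swapping the group there left the number essentially unchanged. On the two numbers at hand, compound 1 and compound 2 therefore sit within the scatter of each other, with nothing to separate them.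

Compound 3 `CCn1c(C(=O)N[C@@H](CC(=O)O)C(=O)O)ccc1C(CC)(CC)c1ccc(OCS(=O)(=O)c2ccccc2)c(C)c1` changes the same position again: 1,2-dicarboxyethyl in place of 2-(diethylamino)ethyl on an amide-type nitrogen. Going by the values given here, the one comparable step, from compound 1 to compound 2, was within the scatter, so the expectation for this further swap on the amide-type nitrogen is a step of modest size, if any, and the estimate leans slightly toward a higher number. Compound 3 is thus expected to give about 9500 nM, within a range from 4000 nM to 25000 nM. This estimate corresponds to an expected step of a 1.3-fold higher number from compound 1 to compound 3 (0.12 log units; within the scatter).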

Compound 3, half-maximal inhibitory concentration: > 50000 nM
Compound 3: only a limit was reported; the forecaster's own chance of this, stated with the estimate: 12%; middle value at least 5.2-fold (0.72 log units) away from the limit.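

The amide-type nitrogen is not indifferent to what it carries: 2-(diethylamino)ethyl and 1-(hydroxymethyl)ethyl sit within the scatter of each other, whereas 1,2-dicarboxyethyl stands apart in this assay, with an at least 7.0-fold higher number from compound 1 to compound 3 (0.84 log units; beyond the scatter) and an at least 6.4-fold higher number from compound 2 to compound 3 (0.80 log units; beyond the scatter). So the first swap at this position gave no sign of what the second reveals: this nitrogen can carry a group that separates a compound clearly from the other two. For compound 3 the figure is a limit and not a number, so both steps give only the smallest possible size of the change: the limit of > 50000 nM in this assay, at which 1 of the 3 values shown sits.

The compounds shown leave open whether one carboxylic acid on a shorter chain would give a step of this size, or whether both acid groups are needed. They also leave open whether the methyl ester of the same chain would stand with compound 3 or with compound 1.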